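Lengthening the Pentyl Chain of Compound 2

The compounds below may be only part of what the source reports. "The series", "measured", "known", "first", "only" and "open" are said of these compounds alone.

- compound 1 `CO[C@@H](C(=O)NC1CC[C@@H](OC(=O)c2ccccc2)CNC1=O)[C@H](O)[C@@H](O)[C@H](O)/C=C/C(C)(C)C` gives 370 nM
- compound 2 `CCCCCc1ccc(C(=O)O[C@@H]2CCC(NC(=O)[C@H](OC)[C@H](O)[C@@H](O)[C@H](O)/C=C/C(C)(C)C)C(=O)NC2)cc1` gives 20 nM

In an in vivo functional assay on the whole organism (MDA-MB-435 cells, Homo sapiens) for antiproliferative activity (on this read-out lower numbers stand for stronger inhibition and higher numbers for weaker inhibition), compound 2 has the lower of the two numbers. Compound 3 `CCCCCCCCCCc1ccc(C(=O)O[C@@H]2CCC(NC(=O)[C@H](OC)[C@H](O)[C@@H](O)[C@H](O)/C=C/C(C)(C)C)C(=O)NC2)cc1` differs from compound 2 by pentyl in place of hydrogen on a saturated chain carbon, five bonds along the chain from an aromatic carbon, with pentyl in place of hydrogen on a saturated chain carbon, five bonds along the chain from an aromatic carbon. Among the compounds with values here, only one measured step bears on this change: a 19-fold lower number from compound 1 to compound 2 (1.27 log units; beyond the scatter), which was large and placed pentyl on an aromatic carbon instead. One such step is weak guidance for a change further along the chain, so a much smaller step in the same direction is expected. In this assay the estimated step is a 1.7-fold lower number from compound 2 to compound 3 (0.22 log units; within the scatter), which may not exceed the usual scatter. Compound 3 is expected at 12 nM, within an estimated range of 3 nM to 60 nM.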

Compound 3, half-maximal inhibitory concentration: 30 nM
Beside the measured number, compound 3's estimate is 2.5-fold (0.40 log units) below it, within the range that was stated.
By their numbers in this assay, from the lowest: compounds 2 and 3 (each within the scatter of the next); then compound 1.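

In this assay the further pentyl on the saturated chain carbon, five bonds along the chain from an aromatic carbon, brings no change beyond the scatter (a 1.5-fold higher number from compound 2 to compound 3 (0.18 log units; within the scatter)), so the large effect of pentyl on the aromatic carbon does not continue along the chain. Decyl in place of hydrogen on the aromatic carbon still gives a large step (a 12-fold lower number from compound 1 to compound 3 (1.09 log units; beyond the scatter)). Nothing available explains this flat response to chain length. On these data alone, whether a propyl chain would already reach this level remains open, as does the effect of an amine or a carboxylic acid in place of the chain.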